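Acyl substituent swap: compound 3 to compound 4

A few compounds are considered here, and "the series" means these few. Any claim that something is new, unique, unknown or untested is made for them only; others in the source may bear on it.

Three compounds sharing one core have been run in an ADME assay (liver) for metabolic stability, with Liver microsome (Homo sapiens) as the target, read by LC-MS, using microsomes and NADPH, tested at 1 uM; on this read-out higher numbers stand for a longer-lived compound and lower numbers for a shorter-lived compound. Compound 1 `CC(C)(C)c1cc(NC(=O)[C@@H]2CCCCN2CC2CC2)no1` gives 0.15 h. Compound 2 `CC(C)(C)c1cc(NC(=O)[C@@H]2CCCCN2CC2CCOCC2)no1` gives 0.183 h, and the step of a 1.2-fold higher number from compound 1 to compound 2 (0.09 log units; within the scatter) falls within the scatter, so no order between these two can be read. Compound 3 `CC(C)(C)c1cc(NC(=O)[C@@H]2CCCCN2C(=O)c2ccccc2)no1` gives 0.683 h, the highest of the three numbers; the steps of a 4.6-fold higher number from compound 1 to compound 3 (0.66 log units; beyond the scatter) and a 3.7-fold higher number from compound 2 to compound 3 (0.57 log units; beyond the scatter) both lie beyond the scatter, so compound 3 stands clearly apart from compound 1 and compound 2.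

Compound 4 `CC(C)(C)c1cc(NC(=O)[C@@H]2CCCCN2C(=O)C2CCCCC2)no1` differs from compound 3 by cyclohexyl in place of phenyl on a carbonyl carbon. Going by the values given here, no measured step touches this position with the carbonyl kept in place. The two steps that lead to compound 3, a 4.6-fold higher number from compound 1 to compound 3 (0.66 log units; beyond the scatter) and a 3.7-fold higher number from compound 2 to compound 3 (0.57 log units; beyond the scatter), each exchange a saturated chain on the ring nitrogen for an acyl group and so bear on the carbonyl itself rather than on the ring attached to it. They give no direction for the exchange of phenyl for cyclohexyl. The step expected is a 1.4-fold lower number from compound 3 to compound 4 (0.14 log units; within the scatter), not beyond the scatter. The estimate for compound 4 in this assay is 0.5 h, with a range from 0.25 h to 1 h.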

Compound 4, half-life: 0.483 h
The estimate for compound 4 lay 1.0-fold (0.02 log units) above the measured number, and the stated range covers the measured number.
By their numbers in this assay, from the lowest: compounds 1 and 2 (each within the scatter of the next); then compounds 4 and 3 (each within the scatter of the next).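

In this assay, cyclohexyl in place of phenyl on a carbonyl carbon gives a step within the scatter (a 1.4-fold lower number from compound 3 to compound 4 (0.15 log units; within the scatter)), so this read-out does not separate the non-aromatic ring from the aromatic ring at this position. The gain seen earlier with benzoyl on the ring nitrogen is therefore not confined to that acyl group: cyclohexylcarbonyl also stands beyond the scatter from both saturated chain compounds (a 2.6-fold higher number from compound 2 to compound 4 (0.42 log units; beyond the scatter) and a 3.2-fold higher number from compound 1 to compound 4 (0.51 log units; beyond the scatter)), and none of the four compounds goes against this split between acyl and saturated chain substituents. No measured evidence accounts for either the flat step at the ring or the separation of the acyl compounds from the others.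

Still open, as far as these compounds go, is whether the half-life holds with a much smaller group on the carbonyl carbon, such as methyl, or with a ring carrying an amine or a carboxylic acid. Also open, from the compounds shown here alone, is whether the carbonyl itself is needed, which a sulfonyl link to the same phenyl or cyclohexyl ring would address.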